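Propyl chain on the shared core: compound 4

The source may hold more compounds than are shown below. What is called first, only, known or untested is meant among the compounds shown, and "the series" means these compounds.

The three measured compounds share one core and differ in the group on a nitrogen on an aromatic ring. Compound 1 `CCn1c(-c2ccccc2)nc2c(NC3CCC3)ncnc21` carries cyclobutyl there and in a functional assay on CHO cells for antagonist activity at adenosine receptor A2b (Homo sapiens), read by 33P incorporation, with a stated time of 20 min (a higher number here means a weaker inhibitor, a lower number a stronger inhibitor), compound 1 gives 1440 nM. Compound 3 `CCn1c(-c2ccccc2)nc2c(NC3CCCC3)ncnc21` carries cyclopentyl and gives 5790 nM; compound 2 `CCn1c(-c2ccccc2)nc2c(NC3CCCCC3)ncnc21` carries cyclohexyl and gives 9020 nM. Compound 2 holds the highest of the three numbers, yet the step of a 1.6-fold lower number from compound 2 to compound 3 (0.19 log units; within the scatter) lies within the scatter, while a 6.3-fold higher number from compound 1 to compound 2 (0.80 log units; beyond the scatter) and a 4.0-fold higher number from compound 1 to compound 3 (0.60 log units; beyond the scatter) stand beyond it.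

Compound 4 `CCCn1c(-c2ccccc2)nc2c(NC3CCCCC3)ncnc21` differs from compound 2 by methyl in place of hydrogen on a saturated chain carbon, two bonds along the chain from an aromatic nitrogen. For the measured compounds named here, none of the measured steps touches this part of the molecule; each of them changes only the group on the nitrogen on the aromatic ring, so no direct reading on the longer chain is available. The expectation therefore rests on compound 2 alone, with no step beyond the scatter expected, that is a 1.0-fold lower number from compound 2 to compound 4 (0.00 log units; within the scatter). Compound 4 is accordingly estimated at 9000 nM, with a range from 3000 nM to 27000 nM.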

Compound 4, inhibition constant: 5310 nM
Estimate against measurement, compound 4: 1.7-fold (0.23 log units) above, and the stated range covers the measured number.
By their numbers in this assay, from the lowest: compound 1; then compounds 4, 3 and 2 (each within the scatter of the next).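

In this assay, for the compounds shown here, the step from ethyl to propyl on the aromatic nitrogen gives the first reading at this position: a 1.7-fold lower number from compound 2 to compound 4 (0.23 log units; within the scatter). With cyclohexyl held on the other nitrogen, adding this methyl two bonds along the chain therefore produces no change that can be told from the scatter, whereas changing the group on the nitrogen from cyclobutyl gave a 6.3-fold higher number from compound 1 to compound 2 (0.80 log units; beyond the scatter). No measurement available here explains the result at this position.

The compounds shown leave open whether the same reading holds with cyclobutyl on the nitrogen, as in compound 1, since this single step rests on the cyclohexyl pair alone. They also leave open whether a butyl chain, or a chain ending in an amine or a carboxylic acid, would move the number beyond the scatter.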